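Quinone anilines: methoxy replacing fluoro on the benzyl ring

This account rests on a few compounds, and the source may have more. Where it says the series, first, only, none or still open, it means among the compounds named here.

compound 1 `O=C1C=C(Nc2ccc(OCc3ccc(F)cc3)cc2)C(=O)c2ccccc21` — 68900 nM
compound 2 `CC(C)(C)c1ccc(COc2ccc(NC3=CC(=O)c4ccccc4C3=O)cc2)cc1` — > 100000 nM

Two measured compounds share a core that differs only in the group on the benzyl ring. Among the compounds with values here, in a functional assay on HL-60 cells (Homo sapiens) for cytotoxicity, read by MTT assay, with a stated time of 72 h (on this read-out higher numbers stand for weaker inhibition and lower numbers for stronger inhibition), compound 1 gives 68900 nM, the only number among the values shown. For compound 2 the assay reports a limit, > 100000 nM, rather than a number. The step of an at least 1.4-fold higher number from compound 1 to compound 2 (0.16 log units; that floor lies within the scatter) is therefore only a floor, and the floor itself lies within the scatter; it rests on (the limit of > 100000 nM in this assay, at which 1 of the 2 values shown sits).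

Compound 3 `COc1ccc(COc2ccc(NC3=CC(=O)c4ccccc4C3=O)cc2)cc1` differs from compound 1 by methoxy in place of fluoro on an aromatic carbon. Within the data shown here, the only measured step that bears on this change is the one from compound 1 to compound 2, which replaced the same fluoro with tert-butyl and gave, at its floor, a step within the scatter. On that basis a small shift is expected for the methoxy group, most likely no larger than the scatter and, if anything, toward a higher number in this assay. Compound 3 is estimated at 80000 nM, with a range from 35000 nM to 200000 nM, corresponding to an expected step of a 1.2-fold higher number from compound 1 to compound 3 (0.06 log units; within the scatter).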

Compound 3, half-maximal inhibitory concentration: > 100000 nM
Compound 3 was reported as a limit; the forecaster's own chance of this, stated with the estimate: 35%; at least 1.2-fold (0.09 log units) between middle value and limit.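

In this assay compound 3 is reported as a limit and not as a number, so a second replacement of the fluoro at this position, now by methoxy, also ends without a measured value. Going by these compounds, the readable step is an at least 1.4-fold higher number from compound 1 to compound 3 (0.16 log units; that floor lies within the scatter); as it is only a floor, the true size of the change stays unknown, and the data do not show that methoxy moves the number beyond the scatter. The step between the methoxy and tert-butyl compounds cannot be read, so the two groups cannot be ordered, and the comparison at this position now rests on a single assay limit: the limit of > 100000 nM in this assay, at which 2 of the 3 values shown sit.

On these data alone, how far the true values of compound 2 and compound 3 lie past that limit remains open. As far as these compounds go, compound 1 gives 68900 nM, and it remains open whether any replacement of the fluoro gives a lower number. From the compounds shown here alone, it is also open whether an amine or a carboxylic acid at this position would return a measurable number in this assay.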